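Methyl to fluoro on the aromatic ring of compound 3

This account rests on a few compounds, and the source may have more. Where it says the series, first, only, none or still open, it means among the compounds named here.

- compound 1 `Cn1c2cnc1OCCCCCCCCCOc1ccccc1-2`: 71000 nM
- compound 2 `Cn1c2cnc1OCCCCCCCCCCCOc1ccccc1-2`: 41000 nM
- compound 3 `C=CCCCCOc1ccc(C)cc1-c1cnc(OCCC=C)n1C`: 53000 nM

All three compounds were tested in a functional assay on MCF7 cells (Homo sapiens) for inhibition, read by colorimetric assay and MTT assay, with a stated time of 72 h; on this read-out lower numbers stand for stronger inhibition and higher numbers for weaker inhibition. Compound 3, at 53000 nM, lies within the scatter of both compound 1 and compound 2, so the three numbers form a single group. Compound 4 `C=CCCCCOc1ccc(F)cc1-c1cnc(OCCC=C)n1C` differs from compound 3 in one place: fluoro in place of methyl on an aromatic carbon. It carries fluoro in place of methyl on an aromatic carbon, para to a (hex-5-en-1-yl)oxy group. For the measured compounds named here, no measured pair shows this change, so the data give no direct size for it. No step beyond the scatter is expected in this assay. The expected change is a 1.1-fold lower number from compound 3 to compound 4 (0.03 log units; within the scatter). Compound 4 is estimated at 50000 nM, with an expected range of 25000 nM to 100000 nM.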

Compound 4, half-maximal inhibitory concentration: 43000 nM
The estimate for compound 4 lay 1.2-fold (0.07 log units) above the measured number; low and high end bracket the measured number.
By their numbers in this assay, from the lowest: compounds 2, 4, 3 and 1 (each within the scatter of the next).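

In this assay, the exchange of methyl for fluoro para to a (hex-5-en-1-yl)oxy group gives a 1.2-fold lower number from compound 3 to compound 4 (0.09 log units; within the scatter). For the compounds shown here, this is the first pair in the set that differs in one place, and it shows that this single exchange at this position produces no step beyond the scatter. No measured property is available to explain this result.

On these data alone, whether an amine or a carboxylic acid on the same aromatic carbon would give a step beyond the scatter remains open. So does the outcome of a longer chain in place of the (hex-5-en-1-yl)oxy group.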